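This account rests on a few compounds, and the source may have more. Where it says the series, first, only, none or still open, it means among the compounds named here.

Among the compounds with values here, compound 3 `Fc1cccc(COc2ccc(-c3cc(CN4CCN(Cc5ccc(C(F)(F)F)cc5)CC4)no3)cc2)c1` gives 1300 nM in a functional assay on Huh-7 cells (Homo sapiens) for antiproliferative activity, read by sulforhodamine B assay, with a stated time of 72 h (a higher number here means a weaker inhibitor, a lower number a stronger inhibitor), the second highest of the three numbers so far. Compound 1 `Cc1ccccc1COc1ccc(-c2cc(CN3CCN(Cc4ccc(C(F)(F)F)cc4)CC3)no2)cc1` gives 1200 nM, and the step of a 1.1-fold higher number from compound 1 to compound 3 (0.03 log units; within the scatter) stays within the scatter. Compound 2 `N#Cc1ccccc1COc1ccc(-c2cc(CN3CCN(Cc4ccc(C(F)(F)F)cc4)CC3)no2)cc1` gives 5000 nM, and the step of a 3.8-fold lower number from compound 2 to compound 3 (0.59 log units; beyond the scatter) is the furthest from compound 3. The unmeasured compound 4 `COc1ccc(COc2ccc(-c3cc(CN4CCN(Cc5ccc(C(F)(F)F)cc5)CC4)no3)cc2)cc1` differs from compound 3 by 4-methoxyphenyl in place of 3-fluorophenyl on a saturated chain carbon bound to an oxygen on an aromatic ring. This same place has been varied twice before: the step of a 4.2-fold higher number from compound 1 to compound 2 (0.62 log units; beyond the scatter) was modest, while the fluorophenyl for methylphenyl exchange changed almost nothing. An entering ring that carries one hydrogen-bond acceptor therefore suggests a small rise in the number, at most modest. Compound 4 is expected to show 1800 nM, in the range 800 nM to 4500 nM, an estimated step of a 1.4-fold higher number from compound 3 to compound 4 (0.14 log units; within the scatter).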

Compound 4, half-maximal inhibitory concentration: 3200 nM
Estimate against measurement, compound 4: 1.8-fold (0.25 log units) below, within the range that was stated.
By their numbers in this assay, from the lowest: compounds 1 and 3 (each within the scatter of the next); then compounds 4 and 2 (each within the scatter of the next).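

With 4-methoxyphenyl, a second ring at this place gives a number beyond the scatter from both compound 1 and compound 3 in this assay (a 2.7-fold higher number from compound 1 to compound 4 (0.43 log units; beyond the scatter); a 2.5-fold higher number from compound 3 to compound 4 (0.39 log units; beyond the scatter)). The ring of compound 2 is not separated from it (a 1.6-fold lower number from compound 2 to compound 4 (0.19 log units; within the scatter)), so 4-methoxyphenyl and 2-cyanophenyl read alike here. Nothing shown accounts for this difference. The change from 3-fluorophenyl to 4-methoxyphenyl swaps the substituent and its ring position together, and the two remain inseparable. As far as these compounds go, how a plain phenyl ring, or a phenyl ring carrying an amine or a carboxylic acid, would read at this place stays open.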